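This account rests on a few compounds, and the source may have more. Where it says the series, first, only, none or still open, it means among the compounds named here.

Two compounds of this series have numbers in an in vitro ADME assay on microsomes from liver (Homo sapiens) for metabolic stability; a lower number here means slower removal, a higher number faster removal of the compound. Compound 1 `COC[C@H]1C[C@@H](C(=O)NC[C@H]2CCCO2)CN(Cc2nc(-c3ccccc3)oc2C)C1` gives 40.3 mL.min-1.g-1 and stands lowest of the two; compound 2 `CC[C@@H]1C[C@@H](C(=O)NCc2cccc(N)n2)CN(Cc2nc(-c3ccccc3)oc2C)C1` gives 281 mL.min-1.g-1, a gap beyond the scatter. Among the measured compounds shown here, no pair differing in a single place has been measured, so the step to compound 3 `Cc1oc(-c2ccccc2)nc1CN1CCC[C@@H](C(=O)NC[C@H]2CCCO2)C1` rests on the structural change alone: hydrogen in place of methoxymethyl on a saturated ring carbon. With nothing to calibrate against, the change is expected to give no step beyond the scatter, a 1.2-fold lower number from compound 1 to compound 3 (0.06 log units; within the scatter). Compound 3 is therefore estimated at 35 mL.min-1.g-1 in this assay, with a range of 15 mL.min-1.g-1 to 80 mL.min-1.g-1.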

Compound 3, intrinsic clearance in microsomes: 84 mL.min-1.g-1
Compound 3: the middle estimate sits 2.4-fold (0.38 log units) below what was measured, and the stated range ends below it.
By their numbers in this assay, from the lowest: compound 1; then compound 3; then compound 2.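

In this assay, among the compounds shown here, hydrogen in place of methoxymethyl on this saturated ring carbon gives a 2.1-fold higher number from compound 1 to compound 3 (0.32 log units; beyond the scatter), the first single-place step. The step is modest but beyond the scatter, so this position, two ring bonds from the ring nitrogen, does register in this read-out, with the methoxymethyl compound lower. No measured information bears on the origin of this step.

As far as these compounds go, whether a hydroxymethyl group or a fluorine atom on this carbon would give a similar number remains open. Also open, from the compounds shown here alone, is whether the step carries over when the ((oxolan-2-yl)methyl)carbamoyl group is replaced.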